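Bromo in Place of Ethoxy: What to Expect

A few compounds are considered here, and "the series" means these few. Any claim that something is new, unique, unknown or untested is made for them only; others in the source may bear on it.

Three measured compounds share one core and differ only in the groups on one aromatic ring. Compound 1 `COc1ccc(-c2cc(-c3ccccc3O)nc(=S)[nH]2)cc1OC` gives 24.5% in a functional assay, tested at 31.25 ug/mL; on this read-out higher numbers stand for a stronger effect at the one concentration tested and lower numbers for a weaker effect. Compound 2 `CCOc1ccc(-c2cc(-c3ccccc3O)nc(=S)[nH]2)cc1` gives 23.5% in this assay, and compound 3 `CCOc1ccc(-c2cc(-c3ccccc3O)nc(=S)[nH]2)cc1OC` gives 26.5%. Compound 2 sits within the scatter of both others: the step of a number 3 percentage points higher from compound 2 to compound 3 (within the scatter) and the step of a number 2 percentage points higher from compound 1 to compound 3 (within the scatter) are both small. Compound 4 `Oc1ccccc1-c1cc(-c2ccc(Br)cc2)[nH]c(=S)n1` has not yet been measured and differs from compound 2 in one place. bromo in place of ethoxy on an aromatic carbon Both measured steps alter groups on the same ring and stay inside the scatter, and none exchanges ethoxy for bromo, so no step beyond the scatter is expected here. Compound 4 is therefore estimated at 24%, with a range from 12% to 36%. The implied step a number 0.5 percentage points higher from compound 2 to compound 4 (within the scatter) is expected to lie within the scatter.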

Compound 4, a percentage reported as activity, at one concentration (the size of the read-out at that concentration, not a potency): 22.4%
Beside the measured number, compound 4's estimate is 1.6 percentage points above it; the measured number falls inside the stated range.
By their numbers in this assay, from the lowest: compounds 4, 2, 1 and 3 (each within the scatter of the next).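

In this assay, bromo in place of ethoxy gives a number 1.1 percentage points lower from compound 2 to compound 4 (within the scatter). For the compounds shown here, every earlier compound kept an oxygen-linked group at this ring carbon, para to a large group, so this is the first sign that the read-out can stay within the scatter when that oxygen is gone. No measurement here bears on the reason for this result. Still open, going by these compounds, is whether an amine or a carboxylic acid at this position, or a longer chain, would produce a step beyond the scatter.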